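Cytotoxicity notes: chloro for methyl at compound 3

The source may report more compounds than this note shows. Statements on the series, on what has been measured and on what is new or still open speak of the compounds shown alone.

Three members of the series have numbers in an ADME assay on MT4 cells (Homo sapiens) for cytotoxicity, read by MTT assay; a higher number here means that more compound is tolerated, a lower number that less compound is tolerated. Compound 1 `O=C(CSc1nncnc1-c1ccccc1Cl)c1ccc(Cl)c(Cl)c1` gives 33000 nM. Compound 2 `O=C(CSc1nncnc1-c1ccccc1Cl)Nc1ccc(Cl)cc1Cl` gives 51000 nM, and compound 3 `Cc1ccccc1NC(=O)CSc1nncnc1-c1ccccc1Cl` gives 142000 nM, the highest of the three numbers, with compound 2 nearest and compound 1 furthest. Both measured steps end at compound 3: a 4.3-fold higher number from compound 1 to compound 3 (0.63 log units; beyond the scatter), and a 2.8-fold higher number from compound 2 to compound 3 (0.44 log units; beyond the scatter). Each is beyond the scatter, yet modest in size.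

Compound 4 `O=C(CSc1nncnc1-c1ccccc1Cl)Nc1ccccc1Cl` is the next step and differs from compound 3 in one place only: chloro in place of methyl on an aromatic carbon. Among the compounds with values here, of the measured steps, the one from compound 2 to compound 3 bears most on it: that step also traded chloro substitution on the same ring for a methyl and raised the number by a 2.8-fold higher number from compound 2 to compound 3 (0.44 log units; beyond the scatter). Compound 4 carries 2-chlorophenyl where compound 2 carried 2,4-dichlorophenyl, so the reverse move toward chloro is expected to be smaller than that step and to lower the number only slightly, close to the scatter. Compound 4 is therefore expected to give 90000 nM, within a range from 40000 nM to 200000 nM. This corresponds to an expected 1.6-fold lower number from compound 3 to compound 4 (0.20 log units; within the scatter).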

Compound 4, half-maximal cytotoxic concentration: 90000 nM
The estimate for compound 4 equals the measured number at the digits printed; low and high end bracket the measured number.
By their numbers in this assay, from the lowest: compounds 1, 2, 4 and 3 (each within the scatter of the next, the first and the last beyond it).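

In this assay, within the data shown here, the exchange on this aromatic carbon, ortho to a large group, gives a 1.6-fold lower number from compound 3 to compound 4 (0.20 log units; within the scatter) and so does not separate methyl from chloro at this place, a reading the earlier compounds could not offer. Going from 2,4-dichlorophenyl to 2-chlorophenyl gives a 1.8-fold higher number from compound 2 to compound 4 (0.25 log units; within the scatter) and thereby splits the earlier 2.8-fold higher number from compound 2 to compound 3 (0.44 log units; beyond the scatter) into two parts, neither of which lies beyond the scatter on its own, so that step is seen only when the two changes are taken together. The change on the carbonyl carbon gives a 2.7-fold higher number from compound 1 to compound 4 (0.44 log units; beyond the scatter) and stands beyond the scatter with chloro on the ring, as a 4.3-fold higher number from compound 1 to compound 3 (0.63 log units; beyond the scatter) does with methyl, so for these two compounds the separation from compound 1 holds with either group.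

From the compounds shown here alone, whether methoxy, an amine or a carboxylic acid on this aromatic carbon would move the number beyond the scatter remains open, as does the effect of plain phenyl with no group at this place. Nothing at hand accounts for any of these differences.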